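From Acetamido to Fluoro: One Change, One Expected Number

This account rests on a few compounds, and the source may have more. Where it says the series, first, only, none or still open, it means among the compounds named here.

Of the compounds shown here, three have been tested in an assay on isolated protein for inhibition of DNA topoisomerase 1 (Homo sapiens), tested at 20 uM; on this read-out lower numbers stand for a weaker effect and higher numbers for a stronger effect at the one concentration tested. Compound 1 `COc1cc(O)ccc1/C=C/C(=O)c1ccc(NC(C)=O)cc1` gives 17.3%, the second highest of the three numbers. Compound 2 `COc1ccc(/C=C/C(=O)c2ccc(O)cc2)cc1Br` gives 6.6%, lower than compound 1 by more than the usual scatter, and compound 3 `COc1cc(O)ccc1C(=O)/C=C/c1ccc(F)cc1` gives 61.6%, well above compound 1. Compound 4 `COc1cc(O)ccc1/C=C/C(=O)c1ccc(F)cc1` has not been tested in this assay. It differs from compound 1 in one place: fluoro in place of acetamido on an aromatic carbon. Within the data shown here, no measured pair shows this exact change, so the size of the step is uncertain. A modest rise is expected because compound 3 gives 61.6% while carrying a fluoro group, though the step may stay within the scatter. Compound 4 is expected to give 30%, between 8% and 60%, a step of a number 12.7 percentage points higher from compound 1 to compound 4 (beyond the scatter).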

Compound 4, a percentage reported as inhibition, at one concentration (the size of the read-out at that concentration, not a potency): 9.5%
For compound 4 the middle estimate is 20.5 percentage points above the measured one; the range from low to high includes it.
By their numbers in this assay, from the lowest: compounds 2, 4 and 1 (each within the scatter of the next, the first and the last beyond it); then compound 3.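

Fluoro in place of acetamido on this aromatic carbon gives a number 7.8 percentage points lower from compound 1 to compound 4 (within the scatter) in this assay and so leaves no readable change. At this place, para to a large group, a single fluorine atom and the four heavy atoms of acetamido cannot be told apart on the shared core, even though the hydrogen-bond donor and acceptor counted for acetamido are gone. No measurement shown offers an explanation for this result.

From the compounds shown here alone, whether an amine, a carboxylic acid or a longer chain on this carbon would move the number remains open. So does whether the same change would give a similar step on a different core.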